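The compounds below may be only part of what the source reports. "The series", "measured", "known", "first", "only" and "open" are said of these compounds alone.

The measured compounds, all in a functional assay on DU-145 cells (Homo sapiens) for inhibition, read by trypan blue exclusion, with a stated time of 96 h; on this read-out higher numbers stand for weaker inhibition of growth and lower numbers for stronger inhibition of growth:

compound 1, `O=C(/C(=C\c1ccccc1OCc1ccccc1)SCc1ccc(F)cc1)c1ccc(Cl)cc1`, gives 1000 nM
compound 2, `Cc1ccc(CS(=O)(=O)/C(=C/c2ccccc2OCc2ccccc2)C(=O)c2ccc(Cl)cc2)cc1`, gives 1000 nM
compound 3, `O=C(/C(=C\c1ccccc1OCc1ccccc1)S(=O)(=O)c1ccc(Br)cc1)c1ccc(Cl)cc1`, gives 1000 nM

Compound 2 stands level with the other two on these numbers. The step of no change at the digits printed from compound 1 to compound 2 (within the scatter) and the step of no change at the digits printed from compound 2 to compound 3 (within the scatter) both lie within the scatter, as does the step of no change at the digits printed from compound 1 to compound 3 (within the scatter). Thus exchanging the group on the sulfur, or the sulfanyl for the sulfonyl, left the growth inhibition where it was in the three compounds seen so far.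

Compound 4, `Cc1ccc(CS(=O)(=O)/C(=C/c2ccccc2Br)C(=O)c2ccc(Cl)cc2)cc1`, has not been measured in this assay. It differs from compound 2 in one place: bromo in place of benzyloxy on an aromatic carbon. The change sits on an aromatic carbon of a six-membered aromatic ring of carbon only, ortho to a large group. Within the data shown here, none of the measured steps touches this part of the molecule; the three steps seen all concern the sulfur side of the chain, and all were flat. There is therefore no measured step on which to base an expectation of a shift, and the flat record of compounds 1, 2 and 3 in this assay gives no reason to expect one either. On these data alone, the step of no change at the digits printed from compound 2 to compound 4 (within the scatter) is expected to lie within the scatter, with the uncertainty widened because the change is untested. Compound 4 is estimated at 1000 nM, between 300 nM and 3000 nM.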

Compound 4, concentration for 50% growth inhibition: 25000 nM
For compound 4 the middle estimate is 25-fold (1.40 log units) below the measured one; measured number outside the range, above it.
By their numbers in this assay, from the lowest: compounds 1, 2 and 3 (each within the scatter of the next); then compound 4.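

In this assay, among these compounds, the place on the aromatic ring that carries benzyloxy proves to matter: exchanging benzyloxy for bromo gives a 25-fold higher number from compound 2 to compound 4 (1.40 log units; beyond the scatter) and is the only step in the set that lies beyond the scatter. The steps on the sulfur side had been flat, so growth inhibition in these four compounds responds to this aromatic carbon and not to the sulfur-side changes tested in compounds 1, 2 and 3. The exchange takes away a six-membered aromatic ring of carbon only together with a hydrogen-bond acceptor and leaves a single bromine, but no measurement here explains the loss, and this one step cannot separate the contributions of those parts.

The compounds shown leave open whether a smaller group holding the oxygen, such as methoxy or hydroxy, or a group without it, such as an amine or a benzyl chain, would keep the growth inhibition seen with benzyloxy. Among the compounds shown here, they also leave open whether the sulfur side stays as flat when bromo rather than benzyloxy sits on this carbon, since compound 4 is the only bromo compound of this kind among them.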